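The source may report more compounds than this note shows. Statements on the series, on what has been measured and on what is new or still open speak of the compounds shown alone.

Measured in a functional assay on WM1361 cells (Homo sapiens) for inhibition, read by MTT assay, with a stated time of 24 h; on this read-out higher numbers stand for weaker inhibition and lower numbers for stronger inhibition:
- Compound 1, `O=c1oc2ccccc2c(N2CCN(c3ccccc3)CC2)c1CO`: > 50000 nM, a limit
- Compound 2, `O=c1oc2ccccc2c(N2CCN(c3ccccc3F)CC2)c1CO`: > 50000 nM, a limit
- Compound 3, `O=c1oc2ccccc2c(N2CCN(C(c3ccccc3)c3ccc(Cl)cc3)CC2)c1CO`: 30200 nM

Compound 2 stands at a limit of this assay and has no exact number, and compound 1 shares that position. The series is thus dominated by the limit of > 50000 nM in this assay, at which 2 of the 3 values shown sit. Compound 4, `O=c1oc2ccccc2c(N2CCN(c3ccc(Cl)c(Cl)c3)CC2)c1CO`, carries 3,4-dichlorophenyl in place of 2-fluorophenyl on an amine nitrogen in a ring. For the measured compounds named here, the one measured single-change step is a step that the two limits leave unreadable from compound 1 to compound 2, so it offers no size to carry over. Going by the values given here, the only numerical reading comes from compound 3, at 30200 nM, and this suggests that a measurable value is possible. On that basis, only a small move toward stronger inhibition is expected in this assay, and the reading may well remain at the limit. The estimated change is an at least 1.1-fold lower number from compound 2 to compound 4 (0.04 log units; that floor lies within the scatter). Compound 4 is expected to read 45000 nM. The estimated range for compound 4 runs from 20000 nM to 100000 nM.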

Compound 4, half-maximal inhibitory concentration: 42700 nM
For compound 4 the middle estimate is 1.1-fold (0.02 log units) above the measured one; the range from low to high includes it.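

In this assay, of the three aryl groups on the amine nitrogen in a ring (phenyl, 2-fluorophenyl and 3,4-dichlorophenyl), only the last gives an exact number, as compound 4 gives 42700 nM. Replacing the fluorinated group reads as an at least 1.1-fold lower number from compound 2 to compound 4 (0.06 log units; that floor lies within the scatter), and replacing the unsubstituted one reads as an at least 1.1-fold lower number from compound 1 to compound 4 (0.06 log units; that floor lies within the scatter). Neither step has a fixed size, and neither floor goes beyond the scatter, because both start from a limit: the limit of > 50000 nM in this assay, at which 2 of the 4 values shown sit.

The effect of the fluoro change cannot be read, and the compounds shown do not separate the contributions of the two chlorines in 3,4-dichlorophenyl. They also leave open how a phenyl ring carrying a single chlorine, a methoxyphenyl group or a pyridine ring would read on this nitrogen.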